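Adding a Second Chloro Group: Compound 3 to Compound 4

The source may report more compounds than this note shows. Statements on the series, on what has been measured and on what is new or still open speak of the compounds shown alone.

Measured so far in a functional assay on MDA-MB-231 cells (Homo sapiens) for cytotoxicity, read by MTT assay, with a stated time of 72 h; a lower number here means a stronger inhibitor, a higher number a weaker inhibitor:
Compound 1 `CN(C)CCCNc1nc(-c2ccc(NC(=O)Nc3ccc(Cl)cc3Cl)cc2)nc2ccsc12` gives 1860 nM.
Compound 2 `CCN(CC)CCNc1nc(-c2ccc(NC(=O)Nc3ccccc3F)cc2)nc2ccsc12` gives 580 nM.
Compound 3 `CCN(CC)CCNc1nc(-c2ccc(NC(=O)Nc3ccc(Cl)cc3)cc2)nc2ccsc12` gives 550 nM.

Compound 3 has the lowest number of the three, but its gap to compound 2 lies within the scatter, so these two cannot be ordered; only compound 1 stands clearly apart, with a higher number. Among the measured compounds shown here, the one clean comparison among the measured compounds is the swap of one substituted phenyl group for another, and there a 1.1-fold lower number from compound 2 to compound 3 (0.02 log units; within the scatter), a change too small to count.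

Compound 4 `CCN(CC)CCNc1nc(-c2ccc(NC(=O)Nc3ccc(Cl)cc3Cl)cc2)nc2ccsc12` is compound 3 with a single addition: chloro in place of hydrogen on an aromatic carbon. For the measured compounds named here, no measured pair isolates exactly this change. Compound 1 carries the same 2,4-dichlorophenyl group but also differs from compound 3 elsewhere in the molecule, so its higher number mixes two changes and cannot be laid on the added chloro alone. The clean swap, a 1.1-fold lower number from compound 2 to compound 3 (0.02 log units; within the scatter), suggests that changing the substitution on this ring matters little, while compound 1 hints that the number may rise. Weighing both, compound 4 is expected to give 900 nM, within 400 nM to 2000 nM, a step of a 1.6-fold higher number from compound 3 to compound 4 (0.21 log units; within the scatter) that may or may not clear the scatter.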

Compound 4, half-maximal inhibitory concentration: 2480 nM
Compound 4: middle estimate off by 2.8-fold (0.44 log units), on the low side; measured number above the stated range.
By their numbers in this assay, from the lowest: compounds 3 and 2 (each within the scatter of the next); then compounds 1 and 4 (each within the scatter of the next).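

In this assay, among the compounds shown here, the chloro on the aromatic carbon ortho to a large group gives the first clean reading of this position, a single added atom that clearly shifts the number (a 4.5-fold higher number from compound 3 to compound 4 (0.65 log units; beyond the scatter)), whereas the earlier swap on the same ring did not register. The 2,4-dichlorophenyl group also stands apart from the 2-fluorophenyl group (a 4.3-fold higher number from compound 2 to compound 4 (0.63 log units; beyond the scatter)), so among these compounds it separates from both rings that carry one halogen. With 2,4-dichlorophenyl held fixed, the change from the (dimethylamino)methyl end of the chain to diethylamino does not register (a 1.3-fold higher number from compound 1 to compound 4 (0.12 log units; within the scatter)), so the high number of compound 1 goes with the ring it shares with compound 4 rather than with its chain.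

Nothing given here explains why the added chloro raises the number. Still open, from the compounds shown here alone, is whether the rise needs both chlorines, which a 2-chlorophenyl group would test, and whether a methyl or methoxy group at the same carbon would shift the number in the same way.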